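The source may hold more compounds than are shown below. What is called first, only, known or untested is meant among the compounds shown, and "the series" means these compounds.

In a functional assay on WM-115 cells (Homo sapiens) for cytotoxicity, read by MTT assay, with a stated time of 46 h (on this read-out lower numbers stand for stronger inhibition and higher numbers for weaker inhibition), compound 1 `O=C1/C(=C/c2ccncc2)C(c2ccccc2)Oc2ccccc21` gives 6300 nM, compound 2 `O=C1/C(=C\c2ccncc2)C(c2ccccc2)Oc2ccccc21` gives 4600 nM and compound 3 `O=C1/C(=C\c2ccccc2)C(c2ccccc2)Oc2ccc(O)cc21` gives 9100 nM. Compound 2 thus stands level with the other two, all three numbers lying within the scatter of one another. Compound 4 `O=C1/C(=C\c2ccc(Cl)cc2)C(c2ccccc2)Oc2ccccc21` carries 4-chlorophenyl in place of pyridin-4-yl on a double-bonded chain carbon bound to a double-bonded ring carbon. Within the data shown here, no measured step covers this change. The only one, a 1.4-fold lower number from compound 1 to compound 2 (0.14 log units; within the scatter), concerns the double bond and stays within the scatter. Compound 3 also lacks pyridin-4-yl, and its 9100 nM remains within the scatter of compound 2. No shift beyond the scatter is therefore expected in this assay, in either direction. The estimated step is a 1.2-fold lower number from compound 2 to compound 4 (0.06 log units; within the scatter). For compound 4 the expected value is 4000 nM, with an estimated range of 1500 nM to 10000 nM.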

Compound 4, half-maximal inhibitory concentration: 27400 nM
For compound 4 the middle estimate is 6.9-fold (0.84 log units) below the measured one; the whole stated range lies below it.
By their numbers in this assay, from the lowest: compounds 2, 1 and 3 (each within the scatter of the next); then compound 4.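

In this assay, 4-chlorophenyl in place of pyridin-4-yl on a double-bonded chain carbon bound to a double-bonded ring carbon gives a 6.0-fold higher number from compound 2 to compound 4 (0.77 log units; beyond the scatter). This is the first step beyond the scatter among these compounds, so this place responds to the group it carries, which the double-bond change did not show. Nothing given bears on what lies behind this step. The compounds shown leave open whether the step follows from losing pyridin-4-yl or from gaining the chlorine, and how pyridin-3-yl or 4-methoxyphenyl would fare at this place.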